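An Ether Oxygen Enters the Chain of Compound 1

A few compounds are considered here, and "the series" means these few. Any claim that something is new, unique, unknown or untested is made for them only; others in the source may bear on it.

Measured so far:
compound 1, `CC(C)CCn1c(N2CCN(C)CC2)nc2ccccc21`: 1400 nM
compound 2, `CCOCCn1c(N2CCNCC2)nc2ccccc21`: 11 nM

Both values come from a functional assay on ileum for inhibition of histamine H1 receptor (Cavia porcellus); a lower number here means a stronger inhibitor, a higher number a weaker inhibitor. Compound 1 stands highest of the two numbers; compound 2 gives a far lower one, yet it differs from compound 1 in more than one place, so that pair alone settles nothing. Compound 3, `COCCCn1c(N2CCN(C)CC2)nc2ccccc21`, differs from compound 1 in a single way: methoxymethyl in place of isopropyl on a saturated chain carbon, two bonds along the chain from an aromatic nitrogen. Among the measured compounds shown here, no measured pair isolates this change, so only an expectation is possible. Compound 2, which gives 11 nM, points toward a lower number rather than a higher one. Compound 3 is therefore expected at 300 nM, between 60 nM and 1500 nM, a moderate step of a 4.7-fold lower number from compound 1 to compound 3 (0.67 log units; beyond the scatter) in this assay.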

Compound 3, half-maximal inhibitory concentration: 860 nM
Estimate against measurement, compound 3: 2.9-fold (0.46 log units) below; the range from low to high includes it.
By their numbers in this assay, from the lowest: compound 2; then compounds 3 and 1 (each within the scatter of the next).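

In this assay, methoxymethyl in place of isopropyl on a saturated chain carbon, two bonds along the chain from an aromatic nitrogen, gives a small step (a 1.6-fold lower number from compound 1 to compound 3 (0.21 log units; within the scatter)). At this position, then, swapping this carbon group for one holding an ether oxygen leaves compound 3 indistinguishable from compound 1 in this test. No measurement here offers an explanation for this result.

Still open, on these data alone, is whether an amine or a carboxylic acid in place of methoxymethyl would move the number beyond the scatter. A longer chain at this position remains equally untested here.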